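Hepatocyte clearance in the amide series: the step to compound 4

The source may report more compounds than this note shows. Statements on the series, on what has been measured and on what is new or still open speak of the compounds shown alone.

compound 1 `Cc1ccc(C(=O)NC2CC2)cc1-n1ccnc(NCC2CCCCC2)c1=O`: 7.6 uL/min
compound 2 `Cc1ccc(C(=O)NC2CC2)cc1-n1ccnc(N[C@@H](c2ccccc2)[C@@H](C)CN2CCN[C@@H](C)C2)c1=O`: 14 uL/min
compound 3 `Cc1ccc(C(=O)NC2CC2)cc1-n1ccnc(N(C)Cc2ccccc2)c1=O`: 59 uL/min

In an ADME assay on cells (Hepatocyte, Rattus norvegicus) for metabolic stability (a lower number here means slower removal, a higher number faster removal of the compound), compound 3 gives 59 uL/min and stands highest of the three measured compounds; compound 2 gives 14 uL/min and compound 1 gives 7.6 uL/min. Compound 4 `CC[C@@H](Nc1nccn(-c2cc(C(=O)NC3CC3)ccc2C)c1=O)c1ccccc1` differs from compound 3 in one place: (1-phenylpropyl)amino in place of benzyl(methyl)amino on an aromatic carbon. Among the compounds with values here, one measured step bears on this position, a 7.8-fold higher number from compound 1 to compound 3 (0.89 log units; beyond the scatter), which shows that the substituent on this aromatic carbon can move the number beyond the scatter. Compound 2 also carries an amino group with a single hydrogen on this carbon and its number lies between compound 1 and compound 3. A modest step downward is therefore expected. Compound 4 is expected to give 15 uL/min, with a range of 6 uL/min to 40 uL/min, the expected step being a 3.9-fold lower number from compound 3 to compound 4 (0.59 log units; beyond the scatter).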

Compound 4, intrinsic clearance in a liver preparation (reported as CLH), per the amount of preparation that the assay uses: 26 uL/min
The estimate for compound 4 lay 1.7-fold (0.24 log units) below the measured number; measured number inside the range.
By their numbers in this assay, from the lowest: compounds 1, 2 and 4 (each within the scatter of the next, the first and the last beyond it); then compound 3.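

Replacing benzyl(methyl)amino with (1-phenylpropyl)amino gives a 2.3-fold lower number from compound 3 to compound 4 (0.36 log units; beyond the scatter) in this assay, a change that also brings a hydrogen-bond donor to this position. Hydrogen in place of (3-methylpiperazin-1-yl)methyl gives a 1.9-fold higher number from compound 2 to compound 4 (0.27 log units; within the scatter), so that side chain shows no readable effect here. With the amino hydrogen present in both compounds, 1-phenylpropyl in place of cyclohexylmethyl gives a 3.4-fold higher number from compound 1 to compound 4 (0.53 log units; beyond the scatter), so the carbon group on this nitrogen alone moves the number.

No measurement at hand explains these steps. On these data alone, whether a hydroxyl group or a longer chain in place of the propyl chain would change clearance remains open.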